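Replacing methylcarbamoyl on the weakest of three compounds

The source may report more compounds than this note shows. Statements on the series, on what has been measured and on what is new or still open speak of the compounds shown alone.

Values measured in a functional assay on SiHa cells (Homo sapiens) for antiproliferative activity, read by CCK-8 assay, with a stated time of 72 h (a higher number here means a weaker inhibitor, a lower number a stronger inhibitor), are as follows
- compound 1 (`COc1ccc(-c2cncnc2-c2cc(OC)c(OC)c(OC)c2)cc1Cl`) gives 1330 nM
- compound 2 (`COc1ccc(-c2cncnc2-c2cc(OC)c(OC)c(OC)c2)nc1`) gives 1750 nM
- compound 3 (`CNC(=O)c1ccc(-c2cncnc2-c2cc(OC)c(OC)c(OC)c2)cc1`) gives 10900 nM

Compound 3 has the highest number of the three, so it is the weakest inhibitor here. In compound 4 (`COc1cc(-c2ncncc2-c2ccc(B(O)O)cc2)cc(OC)c1OC`) its methylcarbamoyl leaves, and a new group enters on the same aromatic carbon, para to a large group (a group of 3 heavy atoms (1 boron, 2 oxygen; no ring) in place of a group of 4 heavy atoms (2 carbon, 1 nitrogen, 1 oxygen; no ring), on an aromatic carbon). Among the measured compounds shown here, no measured step covers this swap. For the measured compounds named here, the one measured step (a 1.3-fold higher number from compound 1 to compound 2 (0.12 log units; within the scatter)) exchanges other groups and stays small. Only compound 3 carries methylcarbamoyl, and both compound 1 (1330 nM) and compound 2 (1750 nM) lie lower, so a drop toward them is expected in this assay (a 7.3-fold lower number from compound 3 to compound 4 (0.86 log units; beyond the scatter)). The estimate for compound 4 is 1500 nM (range 200 nM to 9000 nM).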

Compound 4, half-maximal inhibitory concentration: 17500 nM
Estimate against measurement, compound 4: 12-fold (1.07 log units) below; measured number outside the range, above it.
By their numbers in this assay, from the lowest: compounds 1 and 2 (each within the scatter of the next); then compounds 3 and 4 (each within the scatter of the next).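

In this assay, the boron-bearing group and methylcarbamoyl cannot be told apart on this aromatic carbon (a 1.6-fold higher number from compound 3 to compound 4 (0.21 log units; within the scatter)). Changing the whole aromatic group gives far larger gaps (a 10-fold higher number from compound 2 to compound 4 (1.00 log units; beyond the scatter)) and (a 13-fold higher number from compound 1 to compound 4 (1.12 log units; beyond the scatter)), so among these four compounds the lower numbers go with the two methoxy-bearing aromatic groups, and no compound shown goes against this. No supporting data explain this result. From the compounds shown here alone, it remains open whether a methoxy group alone, an amine or a carboxylic acid on this carbon would lower the number.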